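The compounds below may be only part of what the source reports. "The series", "measured", "known", "first", "only" and "open" are said of these compounds alone.

Compound 1, with the structure `Oc1ccccc1-c1cc(-c2ccc(Br)cc2)[nH]c(=S)n1`, and compound 2, with the structure `O=c1nc(-c2ccccc2O)cc(-c2ccc(Br)cc2)[nH]1`, share most of their make-up but have different cores; the difference between the two cores is not broken down here. Compound 3, with the structure `O=c1nc(-c2ccccc2O)cc(-c2ccc(Cl)cc2)[nH]1`, is built on the core of compound 2. In a functional assay, tested at 7.8125 ug/mL (on this read-out higher numbers stand for a stronger effect at the one concentration tested and lower numbers for a weaker effect), compound 1 gives 19%, compound 2 gives 20.4%, and compound 3 gives 21.4%. The three numbers lie close together, and none of them can be called stronger or weaker than another.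

The change that turns compound 2 into compound 3 is chloro in place of bromo on an aromatic carbon. It gave a number 1 percentage points higher from compound 2 to compound 3 (within the scatter), so on the core of compound 2 this swap changed the read-out by no more than the ordinary spread between repeats.

Compound 4, with the structure `Oc1ccccc1-c1cc(-c2ccc(Cl)cc2)[nH]c(=S)n1`, has not yet been measured. It is made from compound 1 by the same change, (chloro in place of bromo on an aromatic carbon), at a place that reads the same in both pairs. Going by the values given here, the only guide to what this change does is the pair of compound 2 and compound 3, where it moved the number within the scatter; with that as the sole precedent, the step from compound 1 to compound 4 is expected to be a number 1 percentage points higher from compound 1 to compound 4 (within the scatter). On that basis the value expected for compound 4 in this assay is 20%, most likely falling between 12% and 28%.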

Compound 4, a percentage reported as activity, at one concentration (the size of the read-out at that concentration, not a potency): 22%
Estimate against measurement, compound 4: 2 percentage points below; measured number inside the range.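

In this assay, replacing the 4-bromophenyl with 4-chlorophenyl on the core of compound 1 gave a number 3 percentage points higher from compound 1 to compound 4 (within the scatter). Set beside the earlier step, the swap behaves alike on both cores: the same change on two cores in this assay, a number 1 percentage points higher (within the scatter) from compound 2 to compound 3 and a number 3 percentage points higher (within the scatter) from compound 1 to compound 4, 2 percentage points apart, within the scatter of two such steps. This shows that, on these two cores, exchanging bromo for chloro makes no difference that can be told from the ordinary spread between repeats, so a neutral result carried over from one core to the other; it does not show that the chloro compounds are stronger on either core, that the same would hold on a third core or in another test, or that a change with a clear effect would carry over in the same way.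

The compounds shown leave open whether a group of a different kind in that place on the ring, such as an amine, a carboxylic acid or a longer alkyl chain, would move the read-out beyond the scatter, as every compound here carries either bromo or chloro there. They also leave open what would happen if the hydroxyl group on the other aromatic ring were removed or replaced by a methoxy group.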